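The compounds below may be only part of what the source reports. "The series", "measured", "known", "first", "only" and "open" are said of these compounds alone.

Three compounds have been measured in a functional assay on Malme-3M cells (Homo sapiens) for cytotoxicity, read by sulforhodamine B assay, with a stated time of 48 h, tested at 0.01 uM; a lower number here means a stronger effect, a higher number a weaker effect of the compound at the concentration tested:

Compound 1, `COc1cc(C)cc(-c2nn(CC#N)cc2-c2ccc(-c3cccc(C(C)=O)c3)nc2)c1`: 85%
Compound 2, `Cc1cc(O)cc(-c2nn(CC#N)cc2-c2ccnc(-c3ccc(Oc4ccccc4)cc3)c2)c1`: 77%
Compound 3, `COc1cc(C)cc(-c2nn(CC#N)cc2-c2ccnc(-c3ccc(N(C)C)cc3)c2)c1`: 91%

On these numbers compound 3 carries the largest value of the three, but its gap to compound 1 lies within the usual scatter, so those two cannot be told apart; its gap to compound 2 lies beyond the scatter. Compound 4, `Cc1cc(O)cc(-c2nn(CC#N)cc2-c2ccnc(-c3ccc(N(C)C)cc3)c2)c1`, has not yet been measured. It differs from compound 3 in one place: hydrogen in place of methyl on an oxygen on an aromatic ring. Within the data shown here, no two measured compounds differ in only one place, so there is no measured step to lean on; compound 2 also carries a hydroxy group but differs from compound 3 elsewhere as well. In this assay a step that is small, downward if anything, or none beyond the scatter is expected. For compound 4 the estimate is 85%, with a range from 70% to 97%. This estimate means an expected step of a number 6 percentage points lower from compound 3 to compound 4 (within the scatter).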

Compound 4, a percentage reported as activity, at one concentration (the size of the read-out at that concentration, not a potency): 92%
Compound 4: middle estimate off by 7 percentage points, on the low side; the measured number falls inside the stated range.
By their numbers in this assay, from the lowest: compounds 2, 1, 3 and 4 (each within the scatter of the next, the first and the last beyond it).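

Going from methoxy to hydroxy on the aromatic ring gives a number 1 percentage points higher from compound 3 to compound 4 (within the scatter) in this assay, so at this position the methyl on the oxygen can go without a change that stands out from the scatter. The other single change, dimethylamino in place of phenoxy on an aromatic carbon, gives a number 15 percentage points higher from compound 2 to compound 4 (beyond the scatter) and so a modestly weaker effect at the concentration tested. Nothing at hand explains either step. As far as these compounds go, whether a longer chain such as ethoxy, or an amine, on that aromatic position would also leave the number unmoved remains open. A single low concentration also leaves open how these compounds would compare at higher concentrations.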